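The source may hold more compounds than are shown below. What is called first, only, known or untested is meant among the compounds shown, and "the series" means these compounds.

Of the compounds shown here, two have so far been measured in an ADME assay on HEK-293T cells (Homo sapiens) for inhibition, read by CCK-8 assay, with a stated time of 48 h, tested at 20 uM; a higher number here means more inhibition of growth at the concentration tested, a lower number less inhibition of growth. Compound 1 `Cc1ccc(S(=O)(=O)Oc2ccccc2/C=C(\C#N)C(=O)Nc2nnc(C)s2)cc1` gives 35% there. Compound 2 `COc1ccc(Cc2nnc(NC(=O)/C(C#N)=C/c3ccccc3OS(=O)(=O)c3ccc(C)cc3)s2)cc1` gives 21% in this assay, which is the lower of the two numbers; the step of a number 14 percentage points lower from compound 1 to compound 2 (beyond the scatter) shows how far it sits from compound 1. Compound 3 `COc1ccc(Cc2nnc(NC(=O)/C(C#N)=C/c3ccccc3OS(=O)(=O)c3ccc(F)cc3)s2)cc1` has not yet been measured. It differs from compound 2 in a single place: fluoro in place of methyl on an aromatic carbon. Among the compounds with values here, the only measured step, a number 14 percentage points lower from compound 1 to compound 2 (beyond the scatter), concerns a change at a different place in the molecule, so no measured step speaks directly to this exchange. Without a step that bears on it, the expectation for compound 3 is a step of a number 1 percentage points higher from compound 2 to compound 3 (within the scatter) that stays within the usual scatter of repeated measurements. Compound 3 is therefore estimated to give about 22% in this assay, within a range from 8% to 38%.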

Compound 3, percent growth inhibition at one concentration: 6%
The estimate for compound 3 lay 16 percentage points above the measured number; measured number outside the range, below it.
By their numbers in this assay, from the lowest: compound 3; then compound 2; then compound 1.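

The far end of the molecule turns out to matter in this assay: fluoro in place of methyl on the six-membered aromatic ring, para to a large group, gives a number 15 percentage points lower from compound 2 to compound 3 (beyond the scatter). This exchange swaps one heavy atom for one heavy atom and adds no ring, hydrogen-bond donor, hydrogen-bond acceptor or net charge, so even a very small edit at this position can shift the reading beyond the scatter. Nothing shown explains why the number falls.

Going by these compounds, it remains open how a chloro, a methoxy or an amino group would read at this same position. On these data alone, it is also open whether the exchange from 4-methylphenyl to 4-fluorophenyl would lower the number in compound 1, which lacks the 4-methoxyphenyl group.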